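Working notes: hydroxy for nitro, compound 3 to compound 4

A few compounds are considered here, and "the series" means these few. Any claim that something is new, unique, unknown or untested is made for them only; others in the source may bear on it.

Measured so far:
compound 1 `O=C(NN=C(c1ccccc1)c1ccccc1)Nc1nnc(COc2ccc3ccccc3c2)o1` — 300 mg/kg
compound 2 `C/C(=N/NC(=O)Nc1nnc(COc2ccc3ccccc3c2)o1)c1ccc(O)cc1` — 300 mg/kg
compound 3 `O=C(N/N=C(/c1ccccc1)c1ccc([N+](=O)[O-])cc1)Nc1nnc(COc2ccc3ccccc3c2)o1` — 300 mg/kg

All three were run in a functional assay on the whole organism (strain Swiss albino) with Mus musculus as the target, in the maximal electroshock model, with a stated time of 4 h; a lower number here means that less compound is needed, a higher number that more compound is needed for the effect. Compound 3 gives 300 mg/kg and stands level with compound 1 and compound 2 within the scatter; its nearest is compound 1 and its furthest compound 2, with no change at the digits reported in either case.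

Compound 4 `O=C(N/N=C(/c1ccccc1)c1ccc(O)cc1)Nc1nnc(COc2ccc3ccccc3c2)o1` is not yet measured. It differs from compound 3 by hydroxy in place of nitro on an aromatic carbon. Among the measured compounds shown here, the one measured step at this position is no change at the digits printed from compound 1 to compound 3 (within the scatter), which was flat. For the measured compounds named here, compound 2, which also carries a hydroxy, gives 300 mg/kg; no step is known between compound 2 and compound 3, so their matching values show only that. The step of no change at the digits printed from compound 3 to compound 4 (within the scatter) is therefore expected to lie within the scatter, given that no change at the digits printed from compound 1 to compound 3 (within the scatter) showed nothing. Compound 4 is estimated at 300 mg/kg, with a range from 150 mg/kg to 600 mg/kg.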

Compound 4, minimum effective dose: 300 mg/kg
The estimate for compound 4 equals the measured number at the digits printed; the range from low to high includes it.
By their numbers in this assay, from the lowest: compounds 1, 2, 3 and 4 (each within the scatter of the next).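

In this assay the change from 4-nitrophenyl to 4-hydroxyphenyl gives no readable shift (no change at the digits printed from compound 3 to compound 4 (within the scatter)), and hydroxy in place of hydrogen reads the same (no change at the digits printed from compound 1 to compound 4 (within the scatter)), so hydrogen, nitro and hydroxy at this place on the aromatic ring are not told apart. Phenyl in place of methyl on the carbon with a double bond to nitrogen is also flat (no change at the digits printed from compound 2 to compound 4 (within the scatter)), which extends the flat reading to a second place in the series. No evidence on hand bears on this result. On these data alone, whether an amine or a carboxylic acid at the same ring place, or a longer chain in place of the methyl, would move the minimum effective dose remains open.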